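The source may report more compounds than this note shows. Statements on the series, on what has been measured and on what is new or still open speak of the compounds shown alone.

Notes on the series: in a functional assay on B16 cells (Mus musculus) for antiproliferative activity, with a stated time of 72 h (on this read-out lower numbers stand for stronger inhibition and higher numbers for weaker inhibition), compound 1 `OC[C@H]1O[C@@H](n2cnc3c(NCc4ccc(F)cc4)ncnc32)[C@H](O)[C@@H]1O` carries the entry "not determined" (no result reported) and offers no number. Compound 2 `OC[C@H]1O[C@@H](n2cnc3c(NCc4ccc(F)cc4F)ncnc32)[C@H](O)[C@@H]1O` stands at > 166000 nM in this assay as a limit of the assay, not a number. Among the measured compounds shown here, no measured step exists yet. Compound 3 `OC[C@H]1O[C@@H](n2cnc3c(NCc4ccc(F)c(F)c4F)ncnc32)[C@H](O)[C@@H]1O` differs from compound 2 by fluoro in place of hydrogen on an aromatic carbon and this is fluoro in place of hydrogen on an aromatic carbon, turning 2,4-difluorophenyl into 2,3,4-trifluorophenyl. In this assay the expected step that the limit leaves unreadable from compound 2 to compound 3 stays within the usual scatter, with no direction favoured. That expectation rests on compound 2 alone, whose > 166000 nM is only a limit. In this assay the estimate for compound 3 is 170000 nM with an expected range from 50000 nM to 400000 nM on repeated measurement.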

Compound 3, half-maximal inhibitory concentration: > 166000 nM
Compound 3 ended at the assay's limit; the forecaster's own chance of this, stated with the estimate: 70%; the middle value lies beyond the limit too.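

No step can be read from compound 2 to compound 3 in this assay, because both values are limits of the assay and not numbers: the limit of > 166000 nM in this assay, at which 2 of the 3 values shown sit.

The compounds shown leave open whether fluoro in place of hydrogen on an aromatic carbon shifts antiproliferative activity in this assay at all.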